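A few compounds are considered here, and "the series" means these few. Any claim that something is new, unique, unknown or untested is made for them only; others in the source may bear on it.

Measured so far in a functional assay on N2a cells (Mus musculus), with a stated time of 48 h, tested at 0.01 uM; a lower number here means a weaker effect, a higher number a stronger effect of the compound at the concentration tested:
compound 1 `C#CC[C@H]1C[C@H](n2cccc2C(C)=O)C(=O)O1` gives 9.04%
compound 2 `C#CC[C@@H]1C[C@H](n2cccc2C(=O)CC)C(=O)O1` gives 11.6%
compound 3 `C#CC[C@H]1C[C@H](n2cccc2C(=O)CC)C(=O)O1` gives 4.63%

Compound 3 stands at the low end of the three numbers, but its gaps to compound 1 and to compound 2 are both within the scatter, so no order among the three can be read from them. Two measured steps lead to compound 3. One is a number 4.4 percentage points lower from compound 1 to compound 3 (within the scatter). The other is a number 7 percentage points lower from compound 2 to compound 3 (within the scatter), and here the fact that compounds 2 and 3 differ only in the configuration as drawn means the two compounds differ in the drawn configuration alone, with no change of groups.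

Compound 4 `C#CC[C@H]1C[C@H](n2cccc2C(=O)C(F)(F)F)C(=O)O1` is not yet measured. Its difference from compound 3 is trifluoromethyl in place of ethyl on a carbonyl carbon. Going by the values given here, no measured step in this set alters a group on the carbonyl carbon bound to the aromatic carbon in this way; the nearest step, from compound 1 to compound 3, exchanges a smaller group at a saturated chain carbon and stayed within the scatter. With no measured precedent beyond that, the step of a number 2.4 percentage points higher from compound 3 to compound 4 (within the scatter) is my own estimate, and I expect it to be none beyond the scatter. Compound 4 is therefore estimated to give 7% in this assay, within a range of 0% to 20%.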

Compound 4, a percentage reported as activity, at one concentration (the size of the read-out at that concentration, not a potency): 7.76%
Estimate against measurement, compound 4: 0.8 percentage points below; the measured number falls inside the stated range.
By their numbers in this assay, from the lowest: compounds 3, 4, 1 and 2 (each within the scatter of the next).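

In this assay, the carbonyl carbon whose other neighbour is an aromatic carbon now has a third group on record: trifluoromethyl in place of ethyl gives a number 3.1 percentage points higher from compound 3 to compound 4 (within the scatter), and trifluoromethyl in place of methyl gives a number 1.3 percentage points lower from compound 1 to compound 4 (within the scatter). The earlier compounds shown here compared only methyl and ethyl at this place, whereas compounds 1, 3 and 4 now show that a fluorine-bearing group with the same drawn configuration also produces no step beyond the scatter, so the read-out at this one concentration does not separate the three groups. Nothing measured here gives a property of these groups that bears on this result, so no cause can be assigned.

Going by these compounds, it remains open whether a longer chain, an amine or a carboxylic acid on this carbonyl carbon would give a step beyond the scatter. Also open is whether trifluoromethyl would read the same with the other drawn configuration, which among the compounds shown is carried only by compound 2, with ethyl at this place.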